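The compounds below may be only part of what the source reports. "The series", "measured", "known", "first", "only" and "open" are said of these compounds alone.

In a functional assay on HepG2 cells (Homo sapiens) for cytotoxicity, read by sulforhodamine B assay, with a stated time of 48 h (a higher number here means a weaker inhibitor, a lower number a stronger inhibitor), three compounds have so far been measured. Compound 1 `Nc1ccc(C(=O)/C=C/c2ccc(O)c(F)c2)cc1-c1ccc(F)cc1` gives 11700 nM, compound 2 `COc1ccc(-c2cc(C(=O)/C=C/c3cccc(OC)c3OC)ccc2N)cc1OC` gives 5360 nM, and compound 3 `COc1cc(/C=C/C(=O)c2ccc(N)c(-c3ccc(F)cc3)c2)cc(Br)c1O` gives 4730 nM. Compound 2 stands second highest of the three numbers: its nearest companion is compound 3, whose value lies within the usual scatter of the method, and its furthest is compound 1, whose higher number lies beyond that scatter.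

Compound 4 `COc1ccc(/C=C/C(=O)c2ccc(N)c(-c3ccc(OC)c(OC)c3)c2)c(OC)c1` has not yet been measured in this assay. It differs from compound 2 in one place: 2,4-dimethoxyphenyl in place of 2,3-dimethoxyphenyl on a double-bonded chain carbon bound to a double-bonded chain carbon. The two compounds hold the same atoms and differ only in how those atoms are joined.

Within the data shown here, no pair of the measured compounds differs in a single place, so no measured step shows how a change of this kind moves the number. The expectation therefore rests on where compound 2 stands. The step of a 1.0-fold higher number from compound 2 to compound 4 (0.01 log units; within the scatter) is expected to be small, with no direction favoured beyond the scatter. Compound 4 is accordingly expected to give about 5500 nM in this assay, with an estimated range from 2200 nM to 14000 nM.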

Compound 4, half-maximal inhibitory concentration: 2130 nM
Beside the measured number, compound 4's estimate is 2.6-fold (0.41 log units) above it; measured number outside the range, below it.
By their numbers in this assay, from the lowest: compound 4; then compounds 3 and 2 (each within the scatter of the next); then compound 1.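

In this assay, putting 2,4-dimethoxyphenyl in place of 2,3-dimethoxyphenyl on a double-bonded chain carbon bound to a double-bonded chain carbon gives a 2.5-fold lower number from compound 2 to compound 4 (0.40 log units; beyond the scatter), a modest change and the first single-place step available in this set. Among these compounds, the number at this position therefore depends on more than which atoms the group holds: the two groups have the same atoms, the same ring and the same counts of hydrogen-bond donors and acceptors, and differ only in how those atoms are joined, yet the step lies beyond the scatter, which the earlier compounds, with no single-place pair among them, could not show. Nothing measured here speaks to the reason for this step.

Among the compounds shown here, since this is the only step, it remains open whether the same exchange would move the number in the same direction and by a similar amount on a different core, such as that of compound 1. From the compounds shown here alone, it also remains open how a dimethylamino group, a carboxylic acid or a longer alkoxy chain such as ethoxy in place of the methoxy groups would fare at this position.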